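The source may report more compounds than this note shows. Statements on the series, on what has been measured and on what is new or still open speak of the compounds shown alone.

Compound 1 `COc1ccc(CN(C(=O)Nc2ccc(C#N)cc2)n2cnnc2)cc1OC` — > 50000 nM in a functional assay on MCF7 cells (Homo sapiens) for cytotoxicity, read by MTT assay, with a stated time of 48 h; a higher number here means a weaker inhibitor, a lower number a stronger inhibitor; this value is a limit of the assay.
Compound 2 `CCc1ccc(NC(=O)N(Cc2cc(OC)c(OC)c(OC)c2)n2cnnc2)cc1` — 24800 nM in this assay.
Compound 3 `COc1ccc(OC)c(CN(C(=O)NC2CCCCC2)n2cnnc2)c1` — > 50000 nM in this assay; this value is a limit of the assay.

Compound 2 is the only one of the three that gives an actual number; the other two sit at the limit of > 50000 nM in this assay, at which 2 of the 3 values shown sit. Compound 4 `COc1cc(CN(C(=O)Nc2ccc(C#N)cc2)n2cnnc2)cc(OC)c1OC` differs from compound 2 in one place: cyano in place of ethyl on an aromatic carbon. No two measured compounds differ in exactly this way, so the size of this step in this assay is not shown by the data. Compound 1 carries the same cyano group on a different core and sits at the limit. That points toward weak inhibition for compound 4 as well. The step of a 1.8-fold higher number from compound 2 to compound 4 (0.26 log units; within the scatter) is expected to run toward weaker inhibition, possibly past what the assay can report. For compound 4 the estimated value is 45000 nM, expected to lie between 15000 nM and 150000 nM.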

Compound 4, half-maximal inhibitory concentration: > 50000 nM
Compound 4: no number, only a limit; the forecaster's own chance of this, stated with the estimate: 55%; middle value at least 1.1-fold (0.04 log units) away from the limit.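

Cyano in place of ethyl, para to a large group, gives a first step at this position in this assay: an at least 2.0-fold higher number from compound 2 to compound 4 (0.30 log units; that floor lies within the scatter). The value of compound 4 is a limit, so this step has only a floor, which lies within the scatter, and the step between compound 1 and compound 4 cannot be read at all. The series now gathers at one ceiling: the limit of > 50000 nM in this assay, at which 3 of the 4 values shown sit.

Still open, on these data alone, is how far the step really reaches, and whether an amine, a carboxylic acid or a longer chain at this position would give a readable number in this assay.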